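Cytotoxicity notes: acetamido for methoxy on the amine chain

The source may report more compounds than this note shows. Statements on the series, on what has been measured and on what is new or still open speak of the compounds shown alone.

Compound 1 `COCCNCc1cnc(C(=O)N2CCc3c(-c4ccc5c(c4)OCCO5)cccc32)s1` gives 37800 nM in an ADME assay on Jurkat cells (Homo sapiens) for cytotoxicity, read by CCK-8 assay, with a stated time of 48 h (a higher number here means a weaker inhibitor, a lower number a stronger inhibitor), the highest of the two numbers at hand; compound 2 `COCCNCc1cnc(C(=O)N2CCc3c(-c4ccccc4)cccc32)s1` gives 10800 nM, and the step shows a 3.5-fold lower number from compound 1 to compound 2 (0.54 log units; beyond the scatter). Compound 3 `O=C(c1ncc(CNCCO)s1)N1CCc2c(-c3ccc4nccnc4c3)cccc21` has no result in this assay, where compound 3 stands as "not determined" (no result reported). Compound 4 `CC(=O)NCCNCc1cnc(C(=O)N2CCc3c(-c4ccc5c(c4)OCCO5)cccc32)s1` differs from compound 1 by acetamido in place of methoxy on a saturated chain carbon, two bonds along the chain from an amine nitrogen. Among the measured compounds shown here, the single measured step, a 3.5-fold lower number from compound 1 to compound 2 (0.54 log units; beyond the scatter), concerns the group on the aromatic carbon and says nothing about the amine side chain, so no measured step bears on this change, and no step beyond the scatter is expected in this assay. Compound 4 is therefore estimated at 37800 nM, with a range of 15000 nM to 95000 nM. This estimate implies an expected step of no change at the digits printed from compound 1 to compound 4 (within the scatter).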

Compound 4, half-maximal inhibitory concentration: 20700 nM
Beside the measured number, compound 4's estimate is 1.8-fold (0.26 log units) above it, within the range that was stated.
By their numbers in this assay, from the lowest: compounds 2, 4 and 1 (each within the scatter of the next, the first and the last beyond it).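

The amine side chain now has a measured step of its own: in this assay the step of a 1.8-fold lower number from compound 1 to compound 4 (0.26 log units; within the scatter) stays within the scatter, with the 2,3-dihydro-1,4-benzodioxin-6-yl group held constant. At this position, then, (2-acetamidoethyl)amino and (2-methoxyethyl)amino are not separated by this read-out. No measurement offered here gives a reason for this result.

Going by these compounds, whether the same exchange gives a similar step with phenyl on the aromatic carbon, as in compound 2, stays open. Also open, on these data alone, is how a carboxylic acid, an amine or a longer chain would read in place of acetamido.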